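Propylsulfanyl in place of butyl: notes on compound 4

The compounds below may be only part of what the source reports. "The series", "measured", "known", "first", "only" and "open" are said of these compounds alone.

Measured in a functional assay (aorta) for antagonist activity, with Oryctolagus cuniculus as the target; on this read-out lower numbers stand for stronger inhibition and higher numbers for weaker inhibition:
- compound 1 `CCCCC1=Nc2ccccc2S(=O)(=O)N1Cc1ccc(-c2ccccc2C(=O)O)cc1` gives 160 nM
- compound 2 `CCCSC1=NS(=O)(=O)c2ccccc2N1Cc1ccc(-c2ccccc2-c2nn[nH]n2)cc1` gives 93 nM
- compound 3 `CCCCC1=NS(=O)(=O)c2ccccc2N1Cc1ccc(-c2ccccc2C(=O)O)cc1` gives 130 nM

Compound 3 stands within the usual scatter of both compound 1 and compound 2. Compound 4 `CCCSC1=NS(=O)(=O)c2ccccc2N1Cc1ccc(-c2ccccc2C(=O)O)cc1` carries propylsulfanyl in place of butyl on a carbon with a double bond to nitrogen. Among the compounds with values here, no measured pair isolates this change. Compound 2 also carries propylsulfanyl and gives 93 nM, though it differs from compound 4 elsewhere. No step beyond the scatter is therefore expected in this assay. The expected change is a 1.2-fold lower number from compound 3 to compound 4 (0.07 log units; within the scatter). For compound 4 the estimated value is 110 nM, with an expected range of 50 nM to 240 nM.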

Compound 4, antagonist equilibrium constant: 20 nM
For compound 4 the middle estimate is 5.5-fold (0.74 log units) above the measured one, outside the stated range (below it).
By their numbers in this assay, from the lowest: compound 4; then compounds 2, 3 and 1 (each within the scatter of the next).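

In this assay propylsulfanyl in place of butyl on a carbon with a double bond to nitrogen gives a 6.5-fold lower number from compound 3 to compound 4 (0.81 log units; beyond the scatter) and so shows that this position, between two ring nitrogen atoms, can respond beyond the scatter. With propylsulfanyl kept, carboxy in place of 2H-tetrazol-5-yl on an aromatic carbon gives a 4.7-fold lower number from compound 2 to compound 4 (0.67 log units; beyond the scatter) and so shows that this second place also counts. Nothing available explains either step.

As far as these compounds go, whether the first step follows the ring-linked sulfur or the chain stays open. Propoxy or pentylsulfanyl at this position would help separate the two.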